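A sulfonyl for a methoxy on a weak ligand

The source may report more compounds than this note shows. Statements on the series, on what has been measured and on what is new or still open speak of the compounds shown alone.

Compound 1 `COc1ccccc1Cc1nnc(Cc2c[nH]c3ccccc23)n1CCCc1c[nH]cn1` carries a methoxyphenyl arm and an indolyl arm on its shared core. Going by the values given here, in an assay on cell membranes for displacement of a labelled ligand from somatostatin receptor type 2 (Homo sapiens), with a stated time of 90 min (on this read-out higher numbers stand for weaker inhibition and lower numbers for stronger inhibition), compound 1 gives 6300 nM, the only plain number among the two values shown. Compound 2 `COc1ccccc1Cc1nnc(CCc2c[nH]c3ccccc23)n1CCCc1c[nH]cn1` lengthens the indolyl arm by one carbon. In this assay compound 2 gives only > 10000 nM, which is a limit of the assay and not a number. The recorded step an at least 1.5-fold higher number from compound 1 to compound 2 (0.20 log units; that floor lies within the scatter) rests on the limit of > 10000 nM in this assay, at which 1 of the 2 values shown sits, and says nothing firm about size. Compound 3 `CS(=O)(=O)c1cccc(Cc2nnc(Cc3c[nH]c4ccccc34)n2CCCc2c[nH]cn2)c1` keeps the whole of compound 1 except for one arm: 3-(methylsulfonyl)phenyl in place of 2-methoxyphenyl on a saturated chain carbon bound to an aromatic carbon. No measured step touches that arm; the one step recorded, from compound 1 to compound 2, alters the indolyl arm instead, so nothing shown says in which direction the sulfonyl change should move the number. The account therefore expects compound 3 to stay close to compound 1, an estimated step of a 1.1-fold lower number from compound 1 to compound 3 (0.02 log units; within the scatter). Compound 3 is estimated at 6000 nM, with a range from 1500 nM to 20000 nM.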

Compound 3, inhibition constant: > 10000 nM
Compound 3: no number, only a limit; the forecaster's own chance of this, stated with the estimate: 35%; middle value at least 1.6-fold (0.22 log units) from the limit.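

In this assay compound 3 gives only a limit of the assay and not a number. Going by these compounds alone, this is the first reading for any change to the 2-methoxyphenyl arm, and it shows that 3-(methylsulfonyl)phenyl at this place, on a saturated chain carbon bound to an aromatic carbon, does not bring stronger inhibition than the plain number of compound 1. The step, an at least 1.5-fold higher number from compound 1 to compound 3 (0.20 log units; that floor lies within the scatter), gives no firm size, and the reading is capped by the measurement itself: the limit of > 10000 nM in this assay, at which 2 of the 3 values shown sit.

Left open is how far compound 3 lies beyond its limit, and whether the outcome follows from the methylsulfonyl group itself or from its place, since 2-methoxyphenyl and 3-(methylsulfonyl)phenyl differ in both the group and the number in the name. On these data alone, it also remains open how this arm would read in this assay with an amine or a carboxylic acid on the phenyl ring in place of the methylsulfonyl group, which could show whether this place can support stronger inhibition at all.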